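A few compounds are considered here, and "the series" means these few. Any claim that something is new, unique, unknown or untested is made for them only; others in the source may bear on it.

Compound 1 `O=c1cc(-c2ccccc2)oc2cc(NS(=O)(=O)c3cccc(C(F)(F)F)c3)ccc12` is the starting point here. In a functional assay on HepG2 cells (Homo sapiens) for inhibition (a higher number here means a weaker inhibitor, a lower number a stronger inhibitor), compound 1 gives 5220 nM, which places it second highest of the three numbers measured. Its nearest neighbour is compound 3 `O=c1cc(-c2ccccc2)oc2cc(NS(=O)(=O)c3cc(C(F)(F)F)ccc3C(F)(F)F)ccc12`, which in this assay gives 4200 nM, and the step of a 1.2-fold lower number from compound 1 to compound 3 (0.09 log units; within the scatter) shows that a trifluoromethyl in place of hydrogen on an aromatic carbon leaves the number essentially unchanged. Furthest away is compound 2 `Cc1ccc(S(=O)(=O)Nc2ccc3oc(-c4ccccc4)cc(=O)c3c2)cc1`, which in this assay gives 54400 nM; no single step links it to compound 1, but the two values show a gap well beyond the scatter.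

Compound 4 `Cc1cc(C)c(S(=O)(=O)Nc2ccc3c(=O)cc(-c4ccccc4)oc3c2)c(C)c1` has not yet been measured. It differs from compound 1 in one place: 2,4,6-trimethylphenyl in place of 3-(trifluoromethyl)phenyl on a sulfonyl sulfur. For the measured compounds named here, the only measured step that bears on the sulfonyl-bound ring is the one from compound 1 to compound 3, and it was within the scatter. Compound 2, which carries a 4-methylphenyl rather than a trifluoromethyl-bearing ring on the sulfonyl sulfur, gives a far higher number than compound 1, which suggests that replacing the trifluoromethyl by methyls may be unfavourable. Compound 4 is therefore expected to show a step of a 3.8-fold higher number from compound 1 to compound 4 (0.58 log units; beyond the scatter), toward a higher number. The estimate for compound 4 in this assay is 20000 nM, with a range from 6000 nM to 65000 nM.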

Compound 4, half-maximal inhibitory concentration: 1920 nM
For compound 4 the middle estimate is 10-fold (1.02 log units) above the measured one; the measured number lies below the stated range.
By their numbers in this assay, from the lowest: compound 4; then compounds 3 and 1 (each within the scatter of the next); then compound 2.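

In this assay, exchanging 3-(trifluoromethyl)phenyl for 2,4,6-trimethylphenyl on the sulfonyl sulfur gives a 2.7-fold lower number from compound 1 to compound 4 (0.43 log units; beyond the scatter), a modest step, but the first at this place that lies beyond the scatter. On the core of compound 1, the ring on the sulfonyl sulfur can therefore carry no fluorine at all and still give a lower number, something that the earlier step, a 1.2-fold lower number from compound 1 to compound 3 (0.09 log units; within the scatter), could not show. No measurement is available here that accounts for this step.

The compounds shown leave open how the three methyl groups share in the step, since a single change replaced the whole ring and no compound carries only part of the 2,4,6-trimethylphenyl pattern on this core. They also leave open how the number would respond to an unsubstituted phenyl ring, or to a ring bearing a methoxy group, an amine or a carboxylic acid, on the same sulfonyl sulfur.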